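Replacing the triazolyl end group with dimethylamino

This account rests on a few compounds, and the source may have more. Where it says the series, first, only, none or still open, it means among the compounds named here.

In a functional assay on SMMC-7721 cells (Homo sapiens) for antiproliferative activity, read by MTT assay, with a stated time of 48 h (on this read-out higher numbers stand for weaker inhibition and lower numbers for stronger inhibition), compound 1 (`Cn1cc(C2=C(c3nn(CCCn4cncn4)c4ncccc34)C(=O)NC2=O)c2ccccc21`) gives > 100000 nM as its reading, which is a limit of the assay and not a number. Compound 2 (`Cn1cc(C2=C(c3nn(CCCn4cncn4)c4ncccc34)C(=O)N(c3ccccc3)C2=O)c2ccccc21`) gives > 100000 nM as its reading, again only a limit. Compound 3 (`Cn1cc(C2=C(c3nn(CCCN4CCCCC4)c4ncccc34)C(=O)N(c3ccc(Cl)cc3)C2=O)c2ccccc21`) gives > 100000 nM as its reading, also only a limit. All the evidence so far is therefore the limit of > 100000 nM in this assay, at which 3 of the 3 values shown sit, and nothing finer.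

Compound 4 (`CN(C)CCCn1nc(C2=C(c3cn(C)c4ccccc34)C(=O)NC2=O)c2cccnc21`) has not yet been measured. It keeps the core of compound 1 and alters the end of the chain. The change is dimethylamino in place of 1H-1,2,4-triazol-1-yl on a saturated chain carbon, three bonds along the chain from an aromatic nitrogen and it amounts to dimethylamino in place of 1H-1,2,4-triazol-1-yl on a saturated chain carbon, three bonds along the chain from an aromatic nitrogen.

Going by the values given here, the one measured step is a step that the two limits leave unreadable from compound 1 to compound 2 and it lies elsewhere in the molecule, so it lends no size to this change. Compound 1 starts from > 100000 nM as a limit, so any readable change can only run towards stronger inhibition. The expected move is an at least 2.5-fold lower number from compound 1 to compound 4 (0.39 log units; beyond the scatter) in that direction, and this expectation carries a wide margin. For compound 4 the estimated value is 40000 nM with an expected range from 6000 nM to 100000 nM and a real chance of another limit.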

Compound 4, half-maximal inhibitory concentration: > 100000 nM
Compound 4 gave a limit, no number (the forecaster's own chance of this, stated with the estimate: 55%); at least 2.5-fold (0.39 log units) between middle value and limit.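

Compound 1 and compound 4 both give only a limit, so no step can be read for dimethylamino in place of 1H-1,2,4-triazol-1-yl. The compounds shown all rest on the same reading: the limit of > 100000 nM in this assay, at which 4 of the 4 values shown sit.

They leave open whether any compound of this kind gives a true number, and so how large any of these changes really is.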